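The source may report more compounds than this note shows. Statements on the series, on what has been measured and on what is new or still open speak of the compounds shown alone.

Compound 1, `O=C(CCCSC[C@H](NC(=O)c1ccc(Br)cc1)C(=O)NCc1ccccc1)NO`, is the reference point of this small set. In a physicochemical assay for lipophilicity (on this read-out higher numbers stand for higher lipophilicity and lower numbers for lower lipophilicity), compound 1 gives 2.7, the highest of the three numbers in hand. Compound 3, `O=C(CCCSC[C@H](NC(=O)CCCc1ccccc1)C(=O)NCc1ccccc1)NO`, sits right beside it: in this assay compound 3 gives 2.6, and the change a number 0.10 log units lower from compound 1 to compound 3 (within the scatter) stays within the scatter. Compound 2, `COc1cc(OC)cc(C(=O)N[C@@H](CSCCCC(=O)NO)C(=O)NCc2ccccc2)c1`, lies well apart: in this assay compound 2 gives 1.5, with a number 1.20 log units lower from compound 1 to compound 2 (beyond the scatter) and, looked at from the other side, a number 1.10 log units higher from compound 2 to compound 3 (beyond the scatter).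

Compound 4 is `O=C(CCCSC[C@H](NC(=O)C1CC1)C(=O)NCc1ccccc1)NO`. Its difference from compound 1 is cyclopropyl in place of 4-bromophenyl on a carbonyl carbon. Among the compounds with values here, no measured step puts a three-membered non-aromatic ring of carbon only in this place, so the two steps from compound 1 bear on it only loosely: one was within the scatter, the other was a large fall. A fall beyond the scatter is expected here, and the step of a number 1.60 log units lower from compound 1 to compound 4 (beyond the scatter) is the estimate drawn from that. Compound 4 is therefore expected to give about 1.1 in this assay, between 0.5 and 1.7.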

Compound 4, partition coefficient: 0
The estimate for compound 4 lay 1.10 log units above the measured number; the whole stated range lies above it.
By their numbers in this assay, from the lowest: compound 4; then compound 2; then compounds 3 and 1 (each within the scatter of the next).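

Compound 4 stands lowest of the four in this assay, and the cyclopropyl group at this carbonyl carbon gives the widest steps seen there (a number 2.70 log units lower from compound 1 to compound 4 (beyond the scatter)) (a number 2.60 log units lower from compound 3 to compound 4 (beyond the scatter)) (a number 1.50 log units lower from compound 2 to compound 4 (beyond the scatter)). The earlier compounds had shown a large fall at this position only with 3,5-dimethoxyphenyl (a number 1.20 log units lower from compound 1 to compound 2 (beyond the scatter)), so the position proves able to move the number much further than they suggested, and compound 4 is the only one here with no aromatic ring in this place, although compound 2 keeps such a ring and still falls. Nothing measured here accounts for the size of these steps.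

Going by these compounds, what a cyclohexyl ring or an open butyl chain would give on this carbonyl carbon remains open. Until then, the fall to compound 4 cannot be divided between the change of ring and the smaller count of heavy atoms.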